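The source may hold more compounds than are shown below. What is called first, only, known or untested is meant among the compounds shown, and "the series" means these compounds.

Measured in an ADME assay on GES1 cells (Homo sapiens) for cytotoxicity, read by MTT assay, with a stated time of 24 h; a lower number here means that less compound is tolerated, a higher number that more compound is tolerated:
- compound 1 `O=c1[nH]cc(S(=O)(=O)Nc2ccccc2-c2cn(-c3ccc(F)cc3)nn2)c(=O)[nH]1`: "not toxic" (no number reported)
- compound 2 `Cc1cccc(-n2cc(-c3ccc(NS(=O)(=O)c4c[nH]c(=O)[nH]c4=O)cc3)nn2)c1`: 28300 nM

Going by the values given here, compound 2 holds the only number so far, as compound 1 was reported without one. Compound 3 `O=c1[nH]cc(S(=O)(=O)Nc2ccc(-c3cn(-c4ccccc4Cl)nn3)cc2)c(=O)[nH]1` has 2-chlorophenyl in place of the 3-methylphenyl on an aromatic nitrogen of compound 2 (2-chlorophenyl in place of 3-methylphenyl on an aromatic nitrogen). Among the compounds with values here, the two groups match in size by heavy-atom count, and no measured pair shows what such a swap does. No shift beyond the scatter is therefore expected in this assay, and no direction can be favoured. The expected result is a 1.1-fold higher number from compound 2 to compound 3 (0.03 log units; within the scatter). For compound 3 the estimate is 30000 nM, within a range of 12000 nM to 75000 nM.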

Compound 3, half-maximal cytotoxic concentration: 16400 nM
Compound 3: middle estimate off by 1.8-fold (0.26 log units), on the high side, and the stated range covers the measured number.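

In this assay, going by these compounds alone, the first comparison at this position, on an aromatic nitrogen of the five-membered ring, gives a 1.7-fold lower number from compound 2 to compound 3 (0.24 log units; within the scatter). So 2-chlorophenyl and 3-methylphenyl, which have the same heavy-atom count, cannot be told apart here by how much compound the cells tolerate. Nothing available explains this result.

Both groups are six-membered aromatic rings of carbon only, so this single step says little about other kinds of group. As far as these compounds go, whether an amine, a carboxylic acid or a longer chain at this position would give a number beyond the scatter remains open.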